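Pyrazolopyridine amides: cytotoxicity notes for a thiophene analogue

A few compounds are considered here, and "the series" means these few. Any claim that something is new, unique, unknown or untested is made for them only; others in the source may bear on it.

Measured so far:
compound 1 `CC(C)n1ncc2c(C(=O)Nc3ccccn3)cc(-c3ccccc3)nc21` — 12500 nM
compound 2 `CC(C)n1ncc2c(C(=O)Nc3c(F)cc(F)cc3F)cc(-c3cccs3)nc21` — > 200000 nM

In an ADME assay on LLC-MK2 cells (Macaca mulatta) for cytotoxicity, read by spectrophotometry and crystal violet staining, with a stated time of 4 days (on this read-out lower numbers stand for higher toxicity in this test and higher numbers for lower toxicity in this test), compound 1 gives 12500 nM. As far as these compounds go, for compound 2 this assay reports only a limit, > 200000 nM, so compound 2 stands at the limit of > 200000 nM in this assay, at which 1 of the 2 values shown sits, and its true value is unknown. Compound 3 `CC(C)n1ncc2c(C(=O)Nc3ccccn3)cc(-c3cccs3)nc21` differs from compound 2 in one place: pyridin-2-yl in place of 2,4,6-trifluorophenyl on an amide-type nitrogen. Within the data shown here, no measured pair shows this change alone, so its direction rests on expectation only; a move toward lower numbers in this assay is expected, estimated as an at least 6.6-fold lower number from compound 2 to compound 3 (0.82 log units; beyond the scatter). Compound 3 is therefore expected at about 30000 nM, within 8000 nM to 200000 nM.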

Compound 3, half-maximal cytotoxic concentration: > 200000 nM
Compound 3 gave a limit, no number (the forecaster's own chance of this, stated with the estimate: 30%); middle value at least 6.6-fold (0.82 log units) from the limit.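

In this assay compound 3 also gives only a limit, > 200000 nM. Among these compounds, with pyridin-2-yl held constant on the amide-type nitrogen, thiophen-2-yl in place of phenyl on an aromatic carbon gives an at least 16-fold higher number from compound 1 to compound 3 (1.20 log units; beyond the scatter), the first readable single change. The change on the amide-type nitrogen, from compound 2 to compound 3, cannot be read, since both values are limits: the limit of > 200000 nM in this assay, at which 2 of the 3 values shown sit.

As far as these compounds go, the true values of compound 2 and compound 3 stay open, as does whether the thiophen-2-yl step holds with 2,4,6-trifluorophenyl on the amide-type nitrogen. Also open, from the compounds shown here alone, is how an amine or a carboxylic acid on that aromatic carbon would read in this assay.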